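Moving the Bromine: From Compound 2 to Compound 3

The source may report more compounds than this note shows. Statements on the series, on what has been measured and on what is new or still open speak of the compounds shown alone.

Compound 1 `Cc1ccccc1S(=O)(=O)NC(C)C1=CC(=O)c2c(O)ccc(O)c2C1=O`: 70 nM
Compound 2 `CC(NS(=O)(=O)c1cccc(Br)c1)C1=CC(=O)c2c(O)ccc(O)c2C1=O`: 160 nM

Among the measured compounds shown here, in a functional assay on HL-60 cells (Homo sapiens) for cytotoxicity, read by MTT assay (a lower number here means a stronger inhibitor, a higher number a weaker inhibitor), compound 2 gives 160 nM, the higher of the two numbers so far, which makes it the weaker inhibitor of the pair. The next compound, compound 3 `CC(NS(=O)(=O)c1ccccc1Br)C1=CC(=O)c2c(O)ccc(O)c2C1=O`, has the same atoms as compound 2, joined differently: 2-bromophenyl in place of 3-bromophenyl on a sulfonyl sulfur. For the measured compounds named here, only one measured step bears on this change: a 2.3-fold higher number from compound 1 to compound 2 (0.36 log units; beyond the scatter). That step is modest, and it replaces 2-methylphenyl with 3-bromophenyl, so the change of group and the change of position cannot be separated. Going by the values given here, no measured pair shows the effect of moving the bromine alone. Even so, compound 3 keeps the bromine of compound 2, while its 2-bromophenyl name shares the leading 2 with the 2-methylphenyl of compound 1, which gives 70 nM. A modest step toward a lower number is therefore expected in this assay, though this rests on very little data. The expected step is a 2.1-fold lower number from compound 2 to compound 3 (0.33 log units; beyond the scatter). Compound 3 is estimated at 75 nM, with an expected range of 30 nM to 190 nM.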

Compound 3, half-maximal inhibitory concentration: 120 nM
Compound 3: middle estimate off by 1.6-fold (0.20 log units), on the low side; the range from low to high includes it.
By their numbers in this assay, from the lowest: compounds 1, 3 and 2 (each within the scatter of the next, the first and the last beyond it).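

This result separates two changes that the first step mixed together, since a 2.3-fold higher number from compound 1 to compound 2 (0.36 log units; beyond the scatter) swapped the group and moved it at the same time. Moving the bromine alone, 2-bromophenyl in place of 3-bromophenyl on the sulfonyl sulfur, gives a 1.3-fold lower number from compound 2 to compound 3 (0.12 log units; within the scatter) in this assay, so this pair shows no measurable effect of that move. Exchanging the group alone, bromo in place of methyl on an aromatic carbon, gives a 1.7-fold higher number from compound 1 to compound 3 (0.23 log units; within the scatter), so neither single change stands clear of the scatter, although the two together do. Nothing available here explains these numbers, so the reason for this pattern stays unknown.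

The compounds shown leave open whether the same small differences would hold for a very different group on that aromatic carbon, such as an amine or a carboxylic acid in place of the bromo or methyl. They also leave open what a longer chain would do there, since only methyl and bromo appear on the aromatic ring attached to the sulfonyl sulfur.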